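The source may hold more compounds than are shown below. What is called first, only, known or untested is meant among the compounds shown, and "the series" means these compounds.

Compound 1 `O=C(COc1ccc2cc(C(O)(C(F)(F)F)C(F)(F)F)c(O)cc2c1)Nc1ccc(-c2ccccc2)cc1`: 3400 nM in an assay on isolated protein for inhibition of receptor-type tyrosine-protein phosphatase C (Homo sapiens), read by spectrophotometry; on this read-out lower numbers stand for stronger inhibition and higher numbers for weaker inhibition
Compound 2 `Oc1cc(-c2ccccc2)ccc1C(O)(C(F)(F)F)C(F)(F)F`: only a limit of the assay, > 500000 nM
Compound 3 `Oc1c(C(O)(C(F)(F)F)C(F)(F)F)ccc2ccccc12`: only a limit of the assay, > 500000 nM

Among the three measured compounds, compound 1 holds the only real number, while the other two sit at the limit of > 500000 nM in this assay, at which 2 of the 3 values shown sit, and give no number at all. Compound 4 `O=C(COc1ccc2cc(C(O)(C(F)(F)F)C(F)(F)F)c(O)cc2c1)Nc1ccccc1` differs from compound 1 by hydrogen in place of phenyl on an aromatic carbon, so that the 4-phenylphenyl group becomes a plain phenyl group. Going by the values given here, no measured pair shows this change, so its effect cannot be read from the data. The expected outcome is a loss of potency, with the step from compound 1 to compound 4 estimated at a 4.4-fold higher number from compound 1 to compound 4 (0.64 log units; beyond the scatter), a step beyond the usual scatter. Compound 4 is therefore expected to give about 15000 nM in this assay, within a range of 4000 nM to 60000 nM.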

Compound 4, half-maximal inhibitory concentration: > 20000 nM
Compound 4 was reported as a limit; the forecaster's own chance of this, stated with the estimate: 15%; middle value at least 1.3-fold (0.12 log units) from the limit.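

Compound 4 gives only a limit of the assay and not a number: the limit of > 20000 nM in this assay, at which 1 of the 4 values shown sits. This is the first change in one place among these compounds, and cutting the 4-phenylphenyl group back to phenyl gives an at least 5.8-fold higher number from compound 1 to compound 4 (0.76 log units; beyond the scatter). The terminal phenyl on compound 1 therefore matters for inhibition in this series, although the full size of the loss cannot be read.

Going by these compounds, it remains open how a methyl group, a chlorine atom or a carboxylic acid in this place would compare with phenyl.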